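The source may hold more compounds than are shown below. What is called first, only, known or untested is meant among the compounds shown, and "the series" means these compounds.

Measured in a toxicity assay on MT4 cells (Homo sapiens) for cytotoxicity, read by MTT assay, with a stated time of 5 days; on this read-out lower numbers stand for higher toxicity in this test and higher numbers for lower toxicity in this test:
- compound 1 `Cc1cc(-c2ccnc3ccccc23)cc(C)c1Nc1ccnc(Nc2ccc(C#N)cc2)n1`: 3500 nM
- compound 2 `Cc1csc(-c2cc(C)c(Nc3ccnc(Nc4ccc(C#N)cc4)n3)c(C)c2)c1`: 34000 nM
- compound 3 `Cc1ncc(-c2cc(C)c(Nc3ccnc(Nc4ccc(C#N)cc4)n3)c(C)c2)cn1`: 3900 nM

Compound 3 sits level with compound 1, since a 1.1-fold higher number from compound 1 to compound 3 (0.05 log units; within the scatter) stays within the usual scatter of this kind of measurement. Compound 2 stands apart, and an 8.7-fold lower number from compound 2 to compound 3 (0.94 log units; beyond the scatter) is a modest step beyond that scatter.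

The next compound, compound 4 `COc1ncc(-c2cc(C)c(Nc3ccnc(Nc4ccc(C#N)cc4)n3)c(C)c2)cn1`, changes one small group on compound 3: methoxy in place of methyl on an aromatic carbon. This puts methoxy in place of methyl, and the rest of the molecule stays the same.

Among the compounds with values here, no measured pair tests this exact swap, so the nearest evidence comes from replacing the whole ring at that spot. Those larger changes gave a 9.7-fold higher number from compound 1 to compound 2 (0.99 log units; beyond the scatter) and a 1.1-fold higher number from compound 1 to compound 3 (0.05 log units; within the scatter), so one was modest and the other was lost in the scatter. A change on a single ring carbon is much smaller than either, and the data give no reason to favour a direction. The expected result is therefore no clear change beyond the scatter, with a 1.2-fold higher number from compound 3 to compound 4 (0.06 log units; within the scatter) as the estimated step. For compound 4 the estimated value is 4500 nM, with an expected range from 1500 nM to 13000 nM.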

Compound 4, half-maximal cytotoxic concentration: 4800 nM
For compound 4 the middle estimate is 1.1-fold (0.03 log units) below the measured one; low and high end bracket the measured number.
By their numbers in this assay, from the lowest: compounds 1, 3 and 4 (each within the scatter of the next); then compound 2.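

In this assay, putting methoxy in place of methyl on the aromatic carbon between two ring nitrogen atoms gives a 1.2-fold higher number from compound 3 to compound 4 (0.09 log units; within the scatter), so this first direct test of a small group at this spot shows no change that can be told from the scatter, even though methoxy, unlike methyl, counts as a hydrogen-bond acceptor. The 2-methoxypyrimidin-5-yl group also stays level with the larger quinolin-4-yl group, at a 1.4-fold higher number from compound 1 to compound 4 (0.14 log units; within the scatter), whereas swapping 4-methylthiophen-2-yl for it gives a 7.1-fold lower number from compound 2 to compound 4 (0.85 log units; beyond the scatter), a modest step beyond the scatter, which leaves compound 2 as the only one of the four standing apart. Nothing measured here explains why the numbers fall this way.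

As far as these compounds go, it remains open whether an amine, a hydroxyl group or a longer chain such as ethoxy on this same carbon would also stay within the scatter of compound 3. The compounds shown also report only this one cell toxicity read-out, so they leave open whether the methoxy swap matters for any other measurement.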